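Swapping a Propyl Amide for a Cyanophenyl Amide

This account rests on a few compounds, and the source may have more. Where it says the series, first, only, none or still open, it means among the compounds named here.

Compound 1 `CCCC(=O)Nc1c(C(O)(C(F)(F)F)C(F)(F)F)ccc2ccccc12` is the reference point. In an assay on LtK cells with ATP-sensitive inward rectifier potassium channel 11 (Homo sapiens) as the target (on this read-out lower numbers stand for an effect already at smaller amounts and higher numbers for an effect only at larger amounts of compound), compound 1 gives 131 nM, the lowest number among the three compounds measured. Compound 2 `CCC(C)C(=O)Nc1c(C(O)(C(F)(F)F)C(F)(F)F)ccc2ccccc12` gives 177000 nM, and compound 3 `CC(C)OC(=O)Nc1c(C(O)(C(F)(F)F)C(F)(F)F)ccc2ccccc12` gives 1160 nM. Both of these differ from compound 1 only in the group attached to the carbonyl carbon of the amide, and both changes pushed the number up: a 1400-fold higher number from compound 1 to compound 2 (3.13 log units; beyond the scatter), and an 8.9-fold higher number from compound 1 to compound 3 (0.95 log units; beyond the scatter).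

Compound 4 `N#Cc1cccc(C(=O)Nc2c(C(O)(C(F)(F)F)C(F)(F)F)ccc3ccccc23)c1` has not yet been measured. It differs from compound 1 in the same place: 3-cyanophenyl in place of propyl on a carbonyl carbon. Among the compounds with values here, no measured pair shows an aromatic ring on this carbonyl carbon, so the closest guide is simply that both recorded alterations at this position raised the number, one modestly and one very strongly. An increase beyond the scatter is therefore expected, though its size is uncertain. For compound 4 the expected step is a 23-fold higher number from compound 1 to compound 4 (1.36 log units; beyond the scatter), which gives an estimated 3000 nM in this assay, with a likely range from 300 nM to 50000 nM.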

Compound 4, half-maximal effective concentration: 12 nM
For compound 4 the middle estimate is 250-fold (2.40 log units) above the measured one; the measured number lies below the stated range.
By their numbers in this assay, from the lowest: compound 4; then compound 1; then compound 3; then compound 2.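

Within the data shown here, compound 4 is the first change at this carbonyl carbon that lowers the number in this assay (an 11-fold lower number from compound 1 to compound 4 (1.04 log units; beyond the scatter)), so propyl is not the best group seen at this place, even though compound 2 and compound 3 both went the other way. The 3-cyanophenyl group also stands well clear of the other two replacements (a 97-fold lower number from compound 3 to compound 4 (1.99 log units; beyond the scatter); a 15000-fold lower number from compound 2 to compound 4 (4.17 log units; beyond the scatter)), which means that with the core held fixed, the choice of group on this carbonyl carbon alone spans a very wide range of numbers. Nothing available explains how the 3-cyanophenyl group achieves this, so the result stands as an observation without a reason.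

The entering group brings in an aromatic ring and a nitrile together, so the compounds shown cannot say which of the two matters, and a plain phenyl group without the nitrile would be the direct way to separate them. On these data alone, it also remains open whether a chlorine or a methoxy group in place of the nitrile, or a pyridine in place of the benzene ring, would keep the number this low.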